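Cytotoxicity of an Isoxazole Ester Series on Vero Cells

A few compounds are considered here, and "the series" means these few. Any claim that something is new, unique, unknown or untested is made for them only; others in the source may bear on it.

Compound 1 `CCOC(=O)c1cc(-c2cccc(OCc3ccccc3)c2)on1` gives in an ADME assay on Vero cells (Chlorocebus sabaeus) for cytotoxicity, with a stated time of 72 h (a higher number here means a weaker inhibitor, a lower number a stronger inhibitor), a value that is only a limit of the assay, > 128000 nM. Compound 2 `CCOC(=O)c1cc(-c2cccc(OCc3cccc(F)c3)c2)on1` likewise reaches only the limit, > 128000 nM. Compound 3 `CCOC(=O)c1cc(-c2cccc(OCc3cccc(C)c3)c2)on1` also sits at the limit, > 128000 nM. The step from compound 1 to compound 2, a step that the two limits leave unreadable from compound 1 to compound 2, and the step from compound 1 to compound 3, a step that the two limits leave unreadable from compound 1 to compound 3, remain unreadable, as does a step that the two limits leave unreadable from compound 2 to compound 3; all three values share (the limit of > 128000 nM in this assay, at which 3 of the 3 values shown sit). Compound 4 `CCOC(=O)c1cc(-c2cccc(OCc3ccc(C(F)(F)F)cc3)c2)on1` differs from compound 1 by trifluoromethyl in place of hydrogen on an aromatic carbon. With every measured change on this ring leaving the limit untouched, compound 4 is expected in this assay to show no readable step, a step that the limit leaves unreadable from compound 1 to compound 4, and to give an estimated 150000 nM, between 60000 nM and 400000 nM.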

Compound 4, half-maximal inhibitory concentration: > 128000 nM
Compound 4 gave a limit, no number; the forecaster's own chance of this, stated with the estimate: 85%; the middle value does not contradict the limit.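

No step can be read from compound 1 to compound 4, since both give only a limit: the limit of > 128000 nM in this assay, at which 4 of the 4 values shown sit. The compounds shown leave open whether any change would bring a readable value in this assay.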